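A few compounds are considered here, and "the series" means these few. Any claim that something is new, unique, unknown or untested is made for them only; others in the source may bear on it.

Measured: compound 1 `CCC1(CC)CC(C)(C)Oc2ccc(NC(=O)Nc3ccc(C(F)(F)F)cc3)cc21` with 93.3%; compound 2 `CC1(C)CC(C)(C)c2cc(NC(=O)Nc3ccc([N+](=O)[O-])cc3)ccc2O1` with 79%.

In a functional assay on A2780 cells (Homo sapiens) for inhibition, with a stated time of 72 h, tested at 10 uM (a higher number here means more inhibition of growth at the concentration tested, a lower number less inhibition of growth), compound 2 gives 79%, the lower of the two numbers; compound 1 gives 93.3%, and that gap lies beyond the scatter. Compound 3 `CC1(C)CC(C)(C)c2cc(NC(=O)Nc3ccc(C#N)cc3)ccc2O1` differs from compound 2 by cyano in place of nitro on an aromatic carbon. Among the measured compounds shown here, no step between measured compounds matches this change, so the expectation rests on compound 2 alone. The expected step is small and downward, a number 7 percentage points lower from compound 2 to compound 3 (within the scatter), hardly beyond the scatter. Compound 3 is estimated at 72%, in the range 50% to 88%.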

Compound 3, percent growth inhibition at one concentration: 93%
Beside the measured number, compound 3's estimate is 21 percentage points below it; the whole stated range lies below it.
By their numbers in this assay, from the lowest: compound 2; then compounds 3 and 1 (each within the scatter of the next).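

In this assay, among the compounds shown here, the change from 4-nitrophenyl to 4-cyanophenyl gives a number 14 percentage points higher from compound 2 to compound 3 (beyond the scatter) and is the first single-place step. This aromatic carbon, para to a large group, therefore responds to the choice of substituent, with cyano giving the higher growth inhibition of this pair. The finding rests on this one pair, and nothing measured here accounts for the step.

On these data alone, whether an amine or a carboxylic acid at the same carbon would hold growth inhibition near that of compound 3 remains open. As far as these compounds go, the effect of cyano on the core of compound 1 also remains open.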